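The compounds below may be only part of what the source reports. "The series", "measured", "known", "first", "only" and "open" are said of these compounds alone.

Of the compounds shown here, two have so far been tested in a functional assay on the whole organism (blood) with Rattus norvegicus as the target, with stated times of 24 h and 1 h, at a dose of 1 mg/kg by the intraperitoneal route; on this read-out higher numbers stand for a stronger effect at the one dose given and lower numbers for a weaker effect. Compound 1 has the structure `CCCNC(=O)NS(=O)(=O)N1CCC(CCNC(=O)c2cc(Cl)ccc2OC)CC1` and gives 24%. Compound 2, with the structure `COc1ncc(Cl)cc1C(=O)NCCC1CCN(S(=O)(=O)NC(=O)NC[C@@H]2C[C@@H]3C=C[C@@H]2C3)CC1`, gives 20% in this assay. The gap between these two figures lies within the usual scatter of repeated measurements, so the two cannot be told apart: compound 2 stands together with compound 1 at the level both have shown. Going by the values given here, no pair among the measured compounds differs in only one place, so there is no measured step to lean on.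

Compound 3, whose structure is `O=C(NC[C@@H]1C[C@@H]2C=C[C@@H]1C2)NS(=O)(=O)N1CCC(CCNC(=O)c2cc(Cl)cc3cccnc23)CC1`, has not yet been measured in this assay. It differs from compound 2 in one place: 6-chloroquinolin-8-yl in place of 5-chloro-2-methoxypyridin-3-yl on a carbonyl carbon. Among the compounds with values here, with only two measured compounds, lying close together, there is nothing in the data to suggest which way this change should move the figure, so no step beyond the scatter is expected. The step that this estimate means, a number 2 percentage points higher from compound 2 to compound 3 (within the scatter), is expected to stay within the scatter. For compound 3 the estimate in this assay is 22%, with a range from 8% to 40%.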

Compound 3, a percentage reported as activity, at one dose (the size of the read-out at that dose, not a potency): 16%
Compound 3: the middle estimate sits 6 percentage points above what was measured, within the range that was stated.
By their numbers in this assay, from the lowest: compounds 3, 2 and 1 (each within the scatter of the next).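

Going by these compounds alone, this is the only measured step so far that changes a single place: 6-chloroquinolin-8-yl in place of 5-chloro-2-methoxypyridin-3-yl on a carbonyl carbon gives a number 4 percentage points lower from compound 2 to compound 3 (within the scatter) in this assay. The read-out therefore cannot be told apart across this change, even though the entering group has 11 heavy atoms rather than 9, adds a six-membered aromatic ring of carbon only, and has 1 hydrogen-bond acceptor rather than 2. So, at the one dose given, this place on the carbonyl carbon takes either group without a step beyond the scatter, and no information is available to explain that result.

The change swaps the ring system and removes the methoxy group in one move, so the effect of each part remains unseparated, and two changes that might cancel each other cannot be ruled out. On these data alone, it also remains open whether a quite different group in this place, such as a phenyl ring carrying a carboxylic acid or an amine, or a plain butyl chain, would move the read-out beyond the scatter.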